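Benzyl in Place of Propyl on the Amine

This account rests on a few compounds, and the source may have more. Where it says the series, first, only, none or still open, it means among the compounds named here.

Measured so far:
compound 1, `CN1CCN(c2cccn3cc(CN(C)[C@H]4CCCc5cccnc54)nc23)CC1` — > 5000 nM in an ADME assay on HOS cells (Homo sapiens) for cytotoxicity; a higher number here means that more compound is tolerated, a lower number that less compound is tolerated
compound 2, `CCCN(Cc1cn2c(N3CCN(C)CC3)cccc2n1)[C@H]1CCCc2cccnc21` — 6700 nM in this assay

Compound 1 gives a limit of the assay, not a number. Among the compounds with values here, compound 2 is the only compound with an outright number. Compound 1 sits at the limit of > 5000 nM in this assay, at which 1 of the 2 values shown sits.

Compound 3, `CN1CCN(c2cccc3nc(CN(Cc4ccccc4)[C@H]4CCCc5cccnc54)cn23)CC1`, has not yet been measured. The change from compound 2 to compound 3 is phenyl in place of ethyl on a saturated chain carbon bound to an amine nitrogen. No step between measured compounds is shown, so the size of the effect is open. A small fall in tolerated concentration is expected, probably within the scatter. The expected step is a 1.5-fold lower number from compound 2 to compound 3 (0.17 log units; within the scatter). For compound 3 the estimate is 4500 nM, ranging from 1500 nM to 12000 nM.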

Compound 3, half-maximal cytotoxic concentration: 9300 nM
Estimate against measurement, compound 3: 2.1-fold (0.32 log units) below; the range from low to high includes it.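

Replacing ethyl with phenyl on a saturated chain carbon bound to an amine nitrogen, which is the same as going from propyl to benzyl, gives in this assay a 1.4-fold higher number from compound 2 to compound 3 (0.14 log units; within the scatter). Within the data shown here, this is the first step that can be read at this position, and it shows that adding a six-membered aromatic ring here leaves the number within the usual scatter. Nothing measured here accounts for this result.

Going by these compounds, whether a carboxylic acid, an amine or a longer chain in this place would shift the number remains open. So does whether any group here can move it beyond the scatter.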